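The source may hold more compounds than are shown below. What is called first, only, known or untested is meant among the compounds shown, and "the series" means these compounds.

Measured so far in a functional assay on HUVEC cells (Homo sapiens) for inhibition; on this read-out higher numbers stand for weaker inhibition and lower numbers for stronger inhibition:

- compound 1 `CN(c1ccc(N/C(S)=N/c2ccccc2)cc1)c1ccnc(Nc2cccc(CS(C)(=O)=O)c2)n1` gives 6 nM
- compound 2 `CN(c1ccc(NC(=O)Nc2cc(C(F)(F)F)ccc2F)cc1)c1ccnc(Nc2cccc(S(N)(=O)=O)c2)n1` gives 10 nM
- compound 3 `CN(c1ccc(NC(=O)Nc2cc(C(F)(F)F)ccc2F)cc1)c1ccnc(Nc2ccc(S(N)(=O)=O)cc2)n1` gives 8 nM

Compound 2, at 10 nM, lies within the scatter of both other compounds, so these three values set no order. Compound 4 `CN(c1ccc(NC(=O)Nc2ccc(OC(F)(F)F)cc2)cc1)c1ccnc(Nc2cccc(S(N)(=O)=O)c2)n1` has not yet been measured. It carries 4-(trifluoromethoxy)phenyl in place of 2-fluoro-5-(trifluoromethyl)phenyl on an amide-type nitrogen. For the measured compounds named here, the only measured single-place step, a 1.3-fold lower number from compound 2 to compound 3 (0.10 log units; within the scatter), is small and within the scatter, but it exchanges 3-sulfamoylphenyl for 4-sulfamoylphenyl and leaves the group on the amide-type nitrogen untouched. No measurement therefore tests this change directly. Although it differs from compound 2 in more than one place, compound 1 still gives 6 nM, so the three compounds offer no sign of a large shift, though they offer only weak evidence. The expected change, a 1.4-fold higher number from compound 2 to compound 4 (0.15 log units; within the scatter), is no step beyond the scatter. For compound 4 the estimated value is 14 nM, with an expected range from 4 nM to 50 nM.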

Compound 4, half-maximal inhibitory concentration: 5 nM
Compound 4: middle estimate off by 2.8-fold (0.45 log units), on the high side, and the stated range covers the measured number.
By their numbers in this assay, from the lowest: compounds 4, 1, 3 and 2 (each within the scatter of the next).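

On the amide-type nitrogen, this assay gives a 2.0-fold lower number from compound 2 to compound 4 (0.30 log units; within the scatter). For the compounds shown here, this is the first reading at this position, and it shows that 4-(trifluoromethoxy)phenyl can stand in place of 2-fluoro-5-(trifluoromethyl)phenyl with no change beyond the scatter, even though the two groups differ in their substituents and where they sit, and the entering group carries 1 hydrogen-bond acceptor where the leaving group carries 0. Nothing given here explains the result.

The compounds shown leave open whether this position would accept groups further from these two fluorinated phenyl rings, such as a phenyl bearing an amine or a carboxylic acid, or a longer chain. They also leave open whether 4-(trifluoromethoxy)phenyl would read the same alongside 4-sulfamoylphenyl.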